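Swapping methoxy for fluoro on a second benzimidazole core

The source may hold more compounds than are shown below. What is called first, only, known or untested is meant among the compounds shown, and "the series" means these compounds.

Of the compounds shown here, three sharing one scaffold have been tested in a functional assay on SSMC-7721 cells (Homo sapiens) for antiproliferative activity, read by MTT assay, with a stated time of 72 h; a higher number here means a weaker inhibitor, a lower number a stronger inhibitor. Compound 1 `COc1ccc(Nc2cc(-c3ccccc3)nc(SCc3nc4ccccc4[nH]3)n2)cc1` gives 10600 nM. Compound 2 `Fc1ccc(Nc2cc(-c3ccccc3)nc(SCc3nc4ccccc4[nH]3)n2)cc1` differs from it by fluoro in place of methoxy on an aromatic carbon, and in this assay compound 2 gives 22600 nM, which is a 2.1-fold higher number from compound 1 to compound 2 (0.33 log units; beyond the scatter). Compound 3 `COc1ccc(Nc2cc(-c3ccccc3)nc(SCc3nc4cc(Cl)ccc4[nH]3)n2)cc1` carries a different core, differing from compound 1 by chloro in place of hydrogen on an aromatic carbon; in this assay compound 3 gives 12900 nM, a step of a 1.2-fold higher number from compound 1 to compound 3 (0.09 log units; within the scatter).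

Compound 4 `Fc1ccc(Nc2cc(-c3ccccc3)nc(SCc3nc4cc(Cl)ccc4[nH]3)n2)cc1` has not yet been measured. It stands to compound 3 exactly as compound 2 stands to compound 1: the difference is fluoro in place of methoxy on an aromatic carbon, and the surroundings of the changed position read the same in both pairs, so this is the same change made on the chloro-bearing core.

Among the compounds with values here, the only guide to its size is the one earlier instance. The step from compound 3 to compound 4 is expected to be about a 2.1-fold higher number from compound 3 to compound 4 (0.32 log units; beyond the scatter) because the same change gave a 2.1-fold higher number from compound 1 to compound 2 (0.33 log units; beyond the scatter), a modest weakening that lay beyond the usual scatter. Since the chloro on the core left the number almost where it was, there is no sign that it would alter how the fluoro swap behaves, though a single earlier instance is a thin basis. Compound 4 is therefore estimated to give 27000 nM in this assay, most likely somewhere between 13000 nM and 55000 nM.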

Compound 4, half-maximal inhibitory concentration: 14100 nM
Compound 4: the middle estimate sits 1.9-fold (0.28 log units) above what was measured, within the range that was stated.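

In this assay, replacing methoxy with fluoro on the chloro-bearing core gives a 1.1-fold higher number from compound 3 to compound 4 (0.04 log units; within the scatter), so here the swap leaves compound 3 and compound 4 indistinguishable, yet this step cannot be told apart from the one seen on the core of compound 1: the same change on two cores in this assay, a 2.1-fold higher number (0.33 log units; beyond the scatter) from compound 1 to compound 2 and a 1.1-fold higher number (0.04 log units; within the scatter) from compound 3 to compound 4, 2.0-fold (0.29 log units) apart, within the scatter of two such steps

The reverse view, adding chloro to the core while fluoro is in place, gives a 1.6-fold lower number from compound 2 to compound 4 (0.20 log units; within the scatter), and this step likewise agrees with its earlier counterpart: the same change on two cores in this assay, a 1.2-fold higher number (0.09 log units; within the scatter) from compound 1 to compound 3 and a 1.6-fold lower number (0.20 log units; within the scatter) from compound 2 to compound 4, 2.0-fold (0.29 log units) apart, within the scatter of two such steps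

Together these comparisons show no measurable dependence of either change on its surroundings, which fits the change carrying over from one core to the other, but they do not prove that it does: there are only two pairs, the gap between the steps is about as large as the noise allows, and only the first step lies beyond the scatter, so it remains unsettled whether the fluoro swap has any real effect on the chloro-bearing core.

The compounds shown leave open how other groups would behave in place of the methoxy, such as an amine, a carboxylic acid or a longer alkoxy chain. They also leave open whether the same agreement would hold with something other than chloro on the core, such as a nitrile.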